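Amino-alcohol series: dibutylamino analogue awaiting antiproliferative read-out

The source may report more compounds than this note shows. Statements on the series, on what has been measured and on what is new or still open speak of the compounds shown alone.

Measured so far:
compound 1 `CCCCCCCCCCCCCC[C@H](OCOC)[C@H](CN(CCCC)CCCC)NC(=O)OC(C)(C)C` — 27.1%
compound 2 `CCCCCCCCCCCCCC[C@H](O)[C@H](CN(C(C)C)C(C)C)NC(=O)OC(C)(C)C` — 25.3%

In a functional assay on MCF7 cells (Homo sapiens) for antiproliferative activity, read by sulforhodamine B assay, with a stated time of 48 h, tested at 10 uM (on this read-out higher numbers stand for more inhibition at the one concentration tested (going by the name of the read-out) and lower numbers for less inhibition), compound 1 gives 27.1%. In this assay compound 2 gives 25.3%, the lowest of the two numbers, with compound 1 as its nearest neighbour at a gap that lies within the scatter. The two compounds differ in more than one place, so their values only show that neither stands apart from the other.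

Compound 3 `CCCCCCCCCCCCCC[C@H](O)[C@H](CN(CCCC)CCCC)NC(=O)OC(C)(C)C` has not been measured in this assay. It differs from compound 2 in one place: dibutylamino in place of diisopropylamino on a saturated chain carbon, two bonds along the chain from an amide-type nitrogen. Compound 1 already carries the dibutylamino group, and its value sits within the scatter of compound 2, so the change is expected to move this assay little, if at all. The step is expected to read a number 1.7 percentage points higher from compound 2 to compound 3 (within the scatter), a step of no size beyond the scatter, in either direction.

Compound 3 is therefore estimated at 27% in this assay, in the range 12% to 42%.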

Compound 3, a percentage reported as inhibition, at one concentration (the size of the read-out at that concentration, not a potency): 21.5%
Compound 3: middle estimate off by 5.5 percentage points, on the high side; measured number inside the range.
By their numbers in this assay, from the lowest: compounds 3, 2 and 1 (each within the scatter of the next).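

In this assay, among the compounds shown here, the first single-place comparison on the amine gives a number 3.8 percentage points lower from compound 2 to compound 3 (within the scatter) for dibutylamino in place of diisopropylamino on a saturated chain carbon, two bonds along the chain from an amide-type nitrogen; on these compounds, this exchange of one open-chain dialkylamino group for another does not separate from the scatter. For the compounds shown here, the first single-place comparison on the oxygen gives a number 5.6 percentage points lower from compound 1 to compound 3 (within the scatter) for hydrogen in place of methoxymethyl on an oxygen on a saturated carbon, so the free hydroxyl and its methoxymethyl ether also remain unseparated in this pair, and neither step establishes a real difference. Nothing available here bears on these two steps or offers an account of them.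

As far as these compounds go, it remains open whether a primary amine or dimethylamino at this place, or a free amine in place of the tert-butyl carbamate, would give a step beyond the scatter. A shorter alkyl chain in place of the long chain shared by these compounds is also an open question, and the single tested concentration gives no potency for any of them.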